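The source may hold more compounds than are shown below. What is called first, only, known or untested is meant among the compounds shown, and "the series" means these compounds.

In a functional assay on B16 cells (Mus musculus) for cytotoxicity, read by MTT assay, with a stated time of 48 h (on this read-out higher numbers stand for weaker inhibition and lower numbers for stronger inhibition), compound 1 (`C=C1CCC[C@]2(C)CCC(c3cn(-c4ccc(C(C)=O)cc4)nn3)=CC[C@@]12C`) gives 61000 nM and compound 2 (`C=C1CCC[C@]2(C)CCC(c3cn(-c4cccc([N+](=O)[O-])c4)nn3)=CC[C@@]12C`) gives 31700 nM on the shared core. Compound 3 (`C=C1CCC[C@]2(C)CCC(c3cn(-c4ccccc4C(C)=O)nn3)=CC[C@@]12C`) gives 42200 nM and stands within the scatter of both, so no order can be drawn among the three. Compound 4 (`C=C1CCC[C@]2(C)CCC(c3cn(-c4ccc(Cl)cc4)nn3)=CC[C@@]12C`) carries 4-chlorophenyl in place of 2-acetylphenyl on an aromatic nitrogen. Three exchanges at that place bear on it: a 1.9-fold lower number from compound 1 to compound 2 (0.28 log units; within the scatter) and a 1.4-fold lower number from compound 1 to compound 3 (0.16 log units; within the scatter) and a 1.3-fold higher number from compound 2 to compound 3 (0.12 log units; within the scatter) all stay within the scatter. Among the measured compounds shown here, no measured compound carries chlorine, so this group itself is untested. No step beyond the scatter is expected in this assay and no direction is assigned. The estimated step is a 1.1-fold lower number from compound 3 to compound 4 (0.02 log units; within the scatter) and stays within the scatter. For compound 4 the expected value is 40000 nM within an estimated range of 20000 nM to 80000 nM on repeat measurement.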

Compound 4, half-maximal inhibitory concentration: 27200 nM
The estimate for compound 4 lay 1.5-fold (0.17 log units) above the measured number, within the range that was stated.
By their numbers in this assay, from the lowest: compounds 4, 2, 3 and 1 (each within the scatter of the next, the first and the last beyond it).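

In this assay, the set now holds its first step beyond the scatter, though a modest one: a 2.2-fold lower number from compound 1 to compound 4 (0.35 log units; beyond the scatter), with chloro in place of acetyl on an aromatic carbon. The other two exchanges on the aromatic nitrogen stay within the scatter: a 1.6-fold lower number from compound 3 to compound 4 (0.19 log units; within the scatter) and a 1.2-fold lower number from compound 2 to compound 4 (0.07 log units; within the scatter). Among the compounds shown here, nothing available accounts for the single larger step.

Open, from the compounds shown here alone, is how an amine or a carboxylic acid in place of chloro on that aromatic carbon would stand in this assay. Also open, going by these compounds, is whether a bromine there would follow chloro.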